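Flipping the hydroxyl-bearing centre in a serine-derived amide

A few compounds are considered here, and "the series" means these few. Any claim that something is new, unique, unknown or untested is made for them only; others in the source may bear on it.

Compound 3, with the structure `CCCCCCCCc1ccc(NC(=O)[C@@H](N)[C@@H](C)O)cc1`, stands at the strong end of what has been measured so far: in an assay on isolated protein for inhibition of sphingosine kinase 1 (Homo sapiens), read by mobility shift assay (on this read-out higher numbers stand for weaker inhibition and lower numbers for stronger inhibition), compound 3 gives 650 nM, the lowest number recorded here. Compound 1 (`CCCCCCCCc1ccc(NC(=O)[C@H](N)CO)cc1`) gives 5000 nM in this assay, and compound 2 (`CCCCCCCCc1ccc(NC(=O)[C@@H](N)CO)cc1`) gives 4300 nM. The step of a 7.7-fold lower number from compound 1 to compound 3 (0.89 log units; beyond the scatter) and the step of a 6.6-fold lower number from compound 2 to compound 3 (0.82 log units; beyond the scatter) both lie beyond the scatter, so compound 3 is the most potent of the measured set.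

Compound 4, with the structure `CCCCCCCCc1ccc(NC(=O)[C@@H](N)[C@H](C)O)cc1`, is the next step. Its change from compound 3 is the two compounds have the same atoms and bonds and differ only in configuration as drawn: 1 of 2 stereo elements differ; a stereocentre at a saturated chain carbon is drawn R in compound 3 and S in compound 4.

Among the compounds with values here, the one measured step that bears on a change of configuration alone is a 1.2-fold lower number from compound 1 to compound 2 (0.07 log units; within the scatter), a step within the scatter, and it is the fact the fact that compounds 1 and 2 differ only in the configuration as drawn that makes it the relevant comparison. On that basis no change beyond the scatter is expected in this assay, in either direction.

Compound 4 is therefore expected to give about 900 nM in this assay, with a range from 300 nM to 2700 nM, which means an expected step of a 1.4-fold higher number from compound 3 to compound 4 (0.14 log units; within the scatter).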

Compound 4, half-maximal inhibitory concentration: 1100 nM
Beside the measured number, compound 4's estimate is 1.2-fold (0.09 log units) below it; low and high end bracket the measured number.
By their numbers in this assay, from the lowest: compounds 3 and 4 (each within the scatter of the next); then compounds 2 and 1 (each within the scatter of the next).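

The step of a 1.7-fold higher number from compound 3 to compound 4 (0.23 log units; within the scatter) shows that in this assay, redrawing this stereocentre from R to S gives no change that can be told from the scatter, and this pair tests configuration alone: the fact that compounds 3 and 4 differ only in the configuration as drawn. Compound 4 also keeps the advantage over the compounds without the methyl, with a 3.9-fold lower number from compound 2 to compound 4 (0.59 log units; beyond the scatter) and a 4.5-fold lower number from compound 1 to compound 4 (0.66 log units; beyond the scatter), both beyond the scatter. So the stronger inhibition seen when the methyl first appeared in compound 3 is not tied to one drawing of this centre, at least with the other stereocentre held as drawn in compounds 3 and 4.

As far as these compounds go, whether the stronger inhibition would hold with an ethyl in place of this methyl, or with a methoxy or an amine in place of the hydroxyl, stays open. Also open, from the compounds shown here alone, is what flipping the other stereocentre would do in these methyl-bearing compounds.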